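Replacing nonyl with 2-(4-methoxyphenyl)ethenyl on the shared core

This account rests on a few compounds, and the source may have more. Where it says the series, first, only, none or still open, it means among the compounds named here.

Measured in a functional assay on cells (T-cell line, Homo sapiens) for inhibition (on this read-out lower numbers stand for stronger inhibition and higher numbers for weaker inhibition), so far
- compound 1 `Clc1ccc(CCCN2CCC(COC(c3ccccc3)c3ccccc3)CC2)cc1` gives 500 nM here
- compound 2 `Cc1ccc(CCCN2CCC(COC(c3ccccc3)c3ccccc3)CC2)cc1` gives 200 nM here
- compound 3 `CCCCCCCCCCN1CCC(COC(c2ccccc2)c2ccccc2)CC1` gives 2600 nM here

Compound 3 has the highest number of the three, which makes it the weakest inhibitor in this small set. Compound 4 `COc1ccc(/C=C/CN2CCC(COC(c3ccccc3)c3ccccc3)CC2)cc1` keeps the shared core and changes one group 2-(4-methoxyphenyl)ethenyl in place of nonyl on a saturated chain carbon bound to an amine nitrogen in a ring so that an aromatic ring returns to the chain.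

Among the compounds with values here, two measured steps bear on this. Both replace a ring-bearing group with heptyl, one giving a 5.2-fold higher number from compound 1 to compound 3 (0.72 log units; beyond the scatter) (modest) and the other 13-fold higher number from compound 2 to compound 3 (1.11 log units; beyond the scatter) (large). Read in reverse, they point towards a lower number for compound 4 in this assay on this change. Within the data shown here, no measured compound carries the double bond or the 4-methoxyphenyl ring, so the size remains uncertain. The expected change is an 8.7-fold lower number from compound 3 to compound 4 (0.94 log units; beyond the scatter) in this estimate. Compound 4 is estimated at 300 nM with an expected range from 90 nM to 1000 nM on this scale.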

Compound 4, half-maximal inhibitory concentration: 4300 nM
Compound 4: middle estimate off by 14-fold (1.16 log units), on the low side, and the stated range ends below it.
By their numbers in this assay, from the lowest: compound 2; then compound 1; then compounds 3 and 4 (each within the scatter of the next).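

In this assay, an aromatic ring on the chain is not enough for stronger inhibition: 2-(4-methoxyphenyl)ethenyl in place of nonyl stays level with it (a 1.7-fold higher number from compound 3 to compound 4 (0.22 log units; within the scatter)). Ring-bearing chains differ widely among themselves at this position (a 22-fold higher number from compound 2 to compound 4 (1.33 log units; beyond the scatter); an 8.6-fold higher number from compound 1 to compound 4 (0.93 log units; beyond the scatter)), so the stronger inhibition of the earlier compounds cannot be credited to the aromatic ring alone. Nothing measured here gives a reason for this. As far as these compounds go, the double bond and the methoxy group enter together in compound 4, so their separate contributions remain open. A saturated 2-(4-methoxyphenyl)ethyl chain would help separate them.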